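Stereochemical inversion at the chain carbon of compound 1

This account rests on a few compounds, and the source may have more. Where it says the series, first, only, none or still open, it means among the compounds named here.

Among the compounds with values here, compound 1 `C=CCc1cc(OC)c(O[C@H](C)[C@@H](OCC)c2ccc(O)c(OC)c2)c(OC)c1` holds the higher of the two numbers so far obtained in an assay on HEK293 cells for agonist activity at transient receptor potential cation channel subfamily M member 8 (Homo sapiens), read by fluorescence and calcium flux, with a stated time of 5 min (a lower number here means that less compound is needed, a higher number that more compound is needed for the effect), where compound 1 gives 1150 nM. Compound 2 `C=CCc1cc(OC)c(OC(C)C(OCCOCCCC)c2ccc(O)c(OC)c2)c(OC)c1` gives 153 nM in this assay. Compound 3 `C=CCc1cc(OC)c(O[C@H](C)[C@@H](OC(C)=O)c2ccc(O)c(OC)c2)c(OC)c1` reaches only a limit in this assay, namely > 10000 nM, which is the limit (the limit of > 10000 nM in this assay, at which 1 of the 3 values shown sits). Within the data shown here, the single measured step, an at least 8.6-fold higher number from compound 1 to compound 3 (0.93 log units; beyond the scatter), concerns the substituent on the oxygen rather than configuration.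

Compound 4 `C=CCc1cc(OC)c(O[C@@H](C)[C@@H](OCC)c2ccc(O)c(OC)c2)c(OC)c1` differs from compound 1 as follows: the two compounds have the same atoms and bonds and differ only in configuration as drawn: 1 of 2 stereo elements differ; a stereocentre at a saturated chain carbon is drawn R in compound 1 and S in compound 4. No measured pair among these compounds differs only in configuration, so the step from compound 1 to compound 4 has no direct precedent here, and its direction cannot be read from the other steps; a change beyond the scatter in either direction remains possible, and the estimate is therefore wide. For compound 4 the expected value in this assay is 1500 nM, with a range from 300 nM to 8000 nM. This estimate corresponds to an expected step of a 1.3-fold higher number from compound 1 to compound 4 (0.12 log units; within the scatter).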

Compound 4, half-maximal effective concentration: 87 nM
For compound 4 the middle estimate is 17-fold (1.24 log units) above the measured one; measured number below the stated range.
By their numbers in this assay, from the lowest: compounds 4 and 2 (each within the scatter of the next); then compound 1. At a limit, above all of these: compound 3.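

Configuration at this saturated chain carbon carries a large effect in this assay: going from R to S gives a 13-fold lower number from compound 1 to compound 4 (1.12 log units; beyond the scatter). No atom or bond changes, so the step belongs to this stereocentre alone: the fact that compounds 1 and 4 differ only in the configuration as drawn. Within the data shown here, until now the only measured step lay in the substituent on the oxygen, and this chain carbon is now a second place where the number responds, here towards less compound needed.

Open, as far as these compounds go, is whether the change from ethyl to acetyl on that oxygen has the same effect with the S configuration, and what the other stereo element, the same in compound 1 and compound 4, contributes. Also open, from the compounds shown here alone, is how an amine in place of ethyl on that oxygen would read with the S configuration.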